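Chloro added to the core phenyl of compound 2

The source may report more compounds than this note shows. Statements on the series, on what has been measured and on what is new or still open speak of the compounds shown alone.

Measured compounds in a functional assay on A549 cells (Homo sapiens) for antiproliferative activity, with a stated time of 72 h; a higher number here means a weaker inhibitor, a lower number a stronger inhibitor:
compound 1 `Cn1c(N2N=C(c3ccccc3)CC2c2ccccc2)nc(-c2ccccc2)c(C#N)c1=O` gives 52900 nM
compound 2 `Cn1c(N2N=C(c3ccc(Cl)cc3)CC2c2ccccc2)nc(-c2ccccc2)c(C#N)c1=O` gives 26900 nM
compound 3 `COc1ccc(C2CC(c3ccc(Cl)cc3)=NN2c2nc(-c3ccccc3)c(C#N)c(=O)n2C)cc1` gives 6070 nM

Compound 2 stands second highest of the three numbers in this assay; its nearest neighbour is reached by a 2.0-fold lower number from compound 1 to compound 2 (0.29 log units; within the scatter) and its furthest by a 4.4-fold lower number from compound 2 to compound 3 (0.65 log units; beyond the scatter).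

Compound 4 `Cn1c(N2N=C(c3ccc(Cl)cc3)CC2c2ccccc2)nc(-c2ccc(Cl)cc2)c(C#N)c1=O` differs from compound 2 by chloro in place of hydrogen on an aromatic carbon. For the measured compounds named here, two measured steps bear on this: the same chloro-for-hydrogen exchange at a different aromatic carbon, a 2.0-fold lower number from compound 1 to compound 2 (0.29 log units; within the scatter), and a methoxy entering at another aromatic carbon, a 4.4-fold lower number from compound 2 to compound 3 (0.65 log units; beyond the scatter). Both lowered the number, the closer analogy only within the scatter. A small lowering, possibly none beyond the scatter, is therefore expected in this assay, a 1.8-fold lower number from compound 2 to compound 4 (0.25 log units; within the scatter). Compound 4 is estimated at 15000 nM, with a range from 6000 nM to 40000 nM.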

Compound 4, half-maximal inhibitory concentration: 43900 nM
The estimate for compound 4 lay 2.9-fold (0.47 log units) below the measured number; the measured number lies above the stated range.
By their numbers in this assay, from the lowest: compound 3; then compounds 2, 4 and 1 (each within the scatter of the next).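

The exchange of phenyl to 4-chlorophenyl, para to a large group, gives a 1.6-fold higher number from compound 2 to compound 4 (0.21 log units; within the scatter) in this assay, so chloro at this position brings no change that can be read. The earlier chloro step at a different aromatic carbon, a 2.0-fold lower number from compound 1 to compound 2 (0.29 log units; within the scatter), also stayed within the scatter, leaving the methoxy step a 4.4-fold lower number from compound 2 to compound 3 (0.65 log units; beyond the scatter) as the only one shown beyond it.

As far as these compounds go, whether methoxy, an amine or a carboxylic acid at this position would move the number beyond the scatter remains open. No measurement shown explains this result.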